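Chain-end exchange on compound 1, expectation for compound 4

The source may hold more compounds than are shown below. What is called first, only, known or untested is meant among the compounds shown, and "the series" means these compounds.

Measured compounds:
compound 1, `COC(=O)CCCNC(=O)CN1CN(c2ccccc2)C2(CCN(C(=O)c3ccc(C4CCCCC4)cc3)CC2)C1=O`, 2500 nM
compound 2, `CC(C)(C)c1ccc(C(=O)N2CCC3(CC2)C(=O)N(CC(=O)NCCCN)CN3c2ccccc2)cc1`, 4200 nM
compound 3, `COC(=O)CCCNC(=O)CN1CN(c2ccccc2)C2(CCN(C(=O)c3ccc(C(C)(C)C)cc3)CC2)C1=O`, "not determined" (no result reported)

The series is read in an assay on HEK293 cells for displacement of a labelled ligand from NPC1-like intracellular cholesterol transporter 1 (Homo sapiens); on this read-out lower numbers stand for stronger inhibition and higher numbers for weaker inhibition. Compound 1 gives 2500 nM, the lower of the two numbers in hand; compound 2 gives 4200 nM, and the gap between compound 1 and compound 2 lies within the scatter, so the two are taken as equivalent. Compound 3 gives "not determined" (no result reported), carries no number and adds nothing to the ordering.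

The step under study leads from compound 1 to compound 4, `CC(C)(C)OC(=O)NCCCNC(=O)CN1CN(c2ccccc2)C2(CCN(C(=O)c3ccc(C4CCCCC4)cc3)CC2)C1=O`. Computed from the two structures, the change is (tert-butoxycarbonyl)amino in place of methoxycarbonyl on a saturated chain carbon, three bonds along the chain from an amide-type nitrogen. The methoxycarbonyl leaves and the (tert-butoxycarbonyl)amino enters, on a saturated chain carbon three bonds along the chain from an amide-type nitrogen; the rest of the shared core is untouched.

Among the measured compounds shown here, no measured pair in the set shows a change of this kind, so the size of the step is not anchored. Compound 2, with a free chain-end nitrogen and a different aromatic substituent, gives 4200 nM, close to compound 1, which suggests the chain end tolerates variation. The step from compound 1 to compound 4 is therefore expected to be small, a 1.2-fold higher number from compound 1 to compound 4 (0.08 log units; within the scatter), with no direction claimed beyond the scatter. Compound 4 is estimated at 3000 nM, within 1000 nM to 9000 nM.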

Compound 4, half-maximal inhibitory concentration: 6000 nM
The estimate for compound 4 lay 2.0-fold (0.30 log units) below the measured number; the range from low to high includes it.
By their numbers in this assay, from the lowest: compounds 1, 2 and 4 (each within the scatter of the next, the first and the last beyond it).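

In this assay, the chain end now has its first single-place comparison: (tert-butoxycarbonyl)amino in place of methoxycarbonyl, on a saturated chain carbon three bonds along the chain from an amide-type nitrogen, gives a 2.4-fold higher number from compound 1 to compound 4 (0.38 log units; beyond the scatter). The position is therefore not indifferent to this exchange, although the step is modest and the result remains a measurable number on this read-out. The entering group has more heavy atoms and carries a hydrogen-bond donor that the leaving group lacks, and this one step cannot separate those two differences, while no measured evidence bears on the origin of the step.

Going by these compounds, how a free amine, a carboxylic acid or a small acetylamino group would read at this chain end on the core of compound 1 remains open, and any of these could help show whether the step follows the size of the group or the presence of the donor. Also open, on these data alone, is whether a longer or shorter chain carrying (tert-butoxycarbonyl)amino would give a number closer to that of the methoxycarbonyl compound.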